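A methoxy group added to compound 3

A few compounds are considered here, and "the series" means these few. Any claim that something is new, unique, unknown or untested is made for them only; others in the source may bear on it.

Values measured in a physicochemical assay, read by spectrophotometry, with a stated time of 6 min (a higher number here means a weaker inhibitor, a lower number a stronger inhibitor), follow
compound 1 (`O=C(CCc1nc2ccccc2c(=O)[nH]1)N/N=C/c1ccc([N+](=O)[O-])cc1`) 220000000 nM
compound 2 (`O=C(CCc1nc2ccccc2c(=O)[nH]1)N/N=C/c1ccc(Cl)cc1`) 185000000 nM
compound 3 (`O=C(CCc1nc2ccccc2c(=O)[nH]1)N/N=C/c1ccccc1`) 265000000 nM

Compound 3 stands within the scatter of both neighbours, with a 1.2-fold higher number from compound 1 to compound 3 (0.08 log units; within the scatter) and a 1.4-fold higher number from compound 2 to compound 3 (0.16 log units; within the scatter) as its steps. Compound 4 (`COc1ccc(/C=N/NC(=O)CCc2nc3ccccc3c(=O)[nH]2)cc1`) carries one change, (methoxy in place of hydrogen on an aromatic carbon), which is methoxy in place of hydrogen on an aromatic carbon, para to a large group. Among the measured compounds shown here, no measured compound carries methoxy. The nearest evidence is the exchange of other groups on an aromatic carbon, where a 1.2-fold lower number from compound 1 to compound 2 (0.08 log units; within the scatter) also stays within the scatter, as do the two steps above. No step beyond the scatter is therefore expected in this assay, and the estimated step is a 1.2-fold lower number from compound 3 to compound 4 (0.06 log units; within the scatter), in either direction within the scatter. Compound 4 is expected at 230000000 nM, within an estimated range of 140000000 nM to 370000000 nM.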

Compound 4, half-maximal inhibitory concentration: 75000000 nM
For compound 4 the middle estimate is 3.1-fold (0.49 log units) above the measured one; measured number below the stated range.
By their numbers in this assay, from the lowest: compound 4; then compounds 2, 1 and 3 (each within the scatter of the next).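

In this assay, the substituent at this place on the ring can move the number beyond the scatter, which the hydrogen, chloro and nitro compounds, all within the scatter of one another, did not show. Methoxy in place of hydrogen gives the largest of the new steps (a 3.5-fold lower number from compound 3 to compound 4 (0.55 log units; beyond the scatter)), and methoxy also separates from the other two groups (a 2.5-fold lower number from compound 2 to compound 4 (0.39 log units; beyond the scatter); a 2.9-fold lower number from compound 1 to compound 4 (0.47 log units; beyond the scatter)). Nothing available bears on the reason for this. The compounds shown leave open whether a hydroxyl, an ethoxy or an amine at this place would also give a lower number.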